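Swapping a sulfur side chain for 2-aminocyclohexyl

A few compounds are considered here, and "the series" means these few. Any claim that something is new, unique, unknown or untested is made for them only; others in the source may bear on it.

- compound 1 `CC(C)c1n[nH]c2c(NCc3ccc(-c4ccccn4)cc3)nc(SC[C@H](O)CN)nc12` gives 63 nM
- compound 2 `CC(C)c1n[nH]c2c(NCc3ccc(-c4ccccn4)cc3)nc(SCCn3ccnc3)nc12` gives 155 nM

Both compounds were tested in a functional assay on HT cells (Homo sapiens) for antiproliferative activity, read by fluorescence, with a stated time of 72 h; a higher number here means a weaker inhibitor of growth, a lower number a stronger inhibitor of growth. Of the two numbers, compound 2 holds the higher, so it is the weaker growth inhibitor of the pair. Among the compounds with values here, the only measured step is a 2.5-fold higher number from compound 1 to compound 2 (0.39 log units; beyond the scatter), which is modest. Along that step, (1H-imidazol-1-yl)methyl takes the place of 2-amino-1-hydroxyethyl on a saturated chain carbon bound to a sulfur.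

The next compound, compound 3 `CC(C)c1n[nH]c2c(NCc3ccc(-c4ccccn4)cc3)nc(SC3CCCCC3N)nc12`, has not been measured yet. Its difference from compound 2 is this: 2-aminocyclohexyl in place of 2-(1H-imidazol-1-yl)ethyl on a sulfur. Like compound 1 (at 63 nM), it carries an amino group on its sulfur side chain, and it has no imidazolyl group. Read backwards, the one measured step therefore points towards a lower number, of similar modest size. However, no measured compound carries the 2-aminocyclohexyl ring, so this remains uncertain. The estimated change is a 2.1-fold lower number from compound 2 to compound 3 (0.32 log units; beyond the scatter). For compound 3 the expected value is 75 nM, with an estimated range from 25 nM to 220 nM.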

Compound 3, concentration for 50% growth inhibition: 139 nM
Compound 3: middle estimate off by 1.9-fold (0.27 log units), on the low side; low and high end bracket the measured number.
By their numbers in this assay, from the lowest: compound 1; then compounds 3 and 2 (each within the scatter of the next).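

In this assay, the step from an imidazole-bearing chain to a saturated carbon ring carrying an amine is a 1.1-fold lower number from compound 2 to compound 3 (0.05 log units; within the scatter), so on this sulfur the 2-(1H-imidazol-1-yl)ethyl and 2-aminocyclohexyl groups cannot be told apart, even though they share little beyond their size in heavy atoms. An amino group on the sulfur side chain is also not enough on its own to give the lowest number of the set: when 2-aminocyclohexyl takes the place of 3-amino-2-hydroxypropyl, the result is a 2.2-fold higher number from compound 1 to compound 3 (0.34 log units; beyond the scatter), a modest step. No outside evidence is available that would account for either result.

The open-chain group of compound 1 differs from the ring of compound 3 in both its hydroxyl group and its shape, so the data cannot say which of these goes with the lower number; a 3-aminopropyl chain without the hydroxyl group would begin to separate the two. Going by these compounds, how a carboxylic acid or a longer amino chain on this sulfur would compare also remains open.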